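Cyclopropylcarbonyl for cyclopropylmethyl on the bridged amine nitrogen

The source may report more compounds than this note shows. Statements on the series, on what has been measured and on what is new or still open speak of the compounds shown alone.

Three compounds of the series have been run in an ADME assay on microsomes from liver (Homo sapiens) for pharmacokinetics; on this read-out lower numbers stand for slow clearance and higher numbers for fast clearance. Compound 1 `CCC(=O)N1CCN(c2nc(-c3cnn(C)c3)ncc2C#N)C[C@H]1C` gives < 16 mL/min/kg, which is a limit of the assay rather than a number. Compound 2 `Cn1cc(-c2ncc(C#N)c(N3CCN(c4cccc(F)c4)C(C)(C)C3)n2)cn1` gives 91 mL/min/kg. Compound 3 `Cn1cc(-c2ncc(C#N)c(N3C[C@@H]4C[C@H]3CN4CC3CC3)n2)cn1` gives < 16 mL/min/kg, again a limit of the assay and not a number. Compound 3 thus sits, together with compound 1, at the limit of < 16 mL/min/kg in this assay, at which 2 of the 3 values shown sit, and only compound 2 returns a numerical read-out. Compound 4 `Cn1cc(-c2ncc(C#N)c(N3C[C@@H]4C[C@H]3CN4C(=O)C3CC3)n2)cn1` is not yet measured. It differs from compound 3 by cyclopropylcarbonyl in place of cyclopropylmethyl on an amine nitrogen in a ring. For the measured compounds named here, no measured pair in the set carries this change, so its size cannot be read from the data; the expected step is a step that the limit leaves unreadable from compound 3 to compound 4, that is, none beyond the scatter. Compound 4 is therefore expected to give 14 mL/min/kg in this assay, within 6 mL/min/kg to 30 mL/min/kg.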

Compound 4, clearance: < 16 mL/min/kg
Compound 4: no number, only a limit; the forecaster's own chance of this, stated with the estimate: 60%; the middle value lies beyond the limit too.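

No step can be read from compound 3 to compound 4, since both results in this assay are limits of the assay and not numbers: the limit of < 16 mL/min/kg in this assay, at which 3 of the 4 values shown sit.

The compounds shown leave open what cyclopropylcarbonyl in place of cyclopropylmethyl does to clearance.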